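Methyl for hydrogen on an imidazolium oxime: an expected shift

A few compounds are considered here, and "the series" means these few. Any claim that something is new, unique, unknown or untested is made for them only; others in the source may bear on it.

Measured compounds:
compound 1, `C[n+]1ccn(CCCC(C)(C)[N+](=O)[O-])c1/C=N/O`, -2.18
compound 2, `CC(Cn1cc[n+](C)c1/C=N/O)NS(=O)(=O)C(F)(F)F`, -0.82
compound 3, `CCC(Cn1cc[n+](C)c1/C=N/O)NS(=O)(=O)C(F)(F)F`, -0.42

In a physicochemical assay for lipophilicity (a lower number here means a more polar compound, a higher number a more lipophilic compound), compound 1 gives the lowest of the three numbers. Compound 2 gives -0.82 and compound 3 gives -0.42; the difference between the core of compound 1 and that of compound 2 is not broken down here. Going by the values given here, the one step measured is methyl in place of hydrogen on a saturated chain carbon, two bonds along the chain from a sulfonamide nitrogen, which gave a number 0.40 log units higher from compound 2 to compound 3 (beyond the scatter).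

Compound 4, `CC[n+]1ccn(CCCC(C)(C)[N+](=O)[O-])c1/C=N/O`, is not yet measured. It differs from compound 1 by methyl in place of hydrogen on a saturated chain carbon bound to an aromatic nitrogen. This is the same kind of change as that from compound 2 to compound 3, but the place differs: there the carbon was two bonds along the chain from a sulfonamide nitrogen, here it is bound to an aromatic nitrogen. Because a number 0.40 log units higher from compound 2 to compound 3 (beyond the scatter), a step of similar size is expected, a number 0.40 log units higher from compound 1 to compound 4 (beyond the scatter). Compound 4 is estimated at -1.78, between -2.2 and -1.3.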

Compound 4, distribution coefficient: -1.8
For compound 4 the middle estimate is 0.02 log units above the measured one; measured number inside the range.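

In this assay the change of hydrogen to methyl gave a step on the core of compound 1 (a number 0.38 log units higher from compound 1 to compound 4 (beyond the scatter)) close in size to the step on the other core (a number 0.40 log units higher from compound 2 to compound 3 (beyond the scatter)), and so it carried over between these two pairs. Going by these compounds alone, this rests on only two pairs, with the change in a different place in each, and it does not establish that the step would hold on other cores or at other places. Nothing shown explains why the two steps are alike.

The compounds shown leave open whether a longer chain such as propyl would extend the step. They also leave open how an amine or a carboxylic acid on that chain would read.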